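Diamine Extension in a Transporter Series

This account rests on a few compounds, and the source may have more. Where it says the series, first, only, none or still open, it means among the compounds named here.

Compound 1 `CCCCCCCCCCc1ccc(-c2noc(CN)n2)cc1`: 62%
Compound 2 `CCCCCCCCCCc1ccc(-c2noc(CCCCN)n2)cc1`: 55%

In an assay on HeLa cells for inhibition of sphingosine-1-phosphate transporter SPNS2 (Mus musculus), read by LC-MS, tested at 2 uM (on this read-out lower numbers stand for less inhibition and higher numbers for more inhibition at the one concentration tested (going by the name of the read-out)), compound 1 gives 62%. Compound 2, in this assay, gives 55%. Compound 2 holds the lower of the two numbers, but the step of a number 7 percentage points lower from compound 1 to compound 2 (within the scatter) lies within the scatter, so the two compounds cannot be told apart on these data. The unmeasured compound 3 `CCCCCCCCCCc1ccc(-c2noc([C@@H](N)CCCCN)n2)cc1` differs from compound 2 in one place: 1,5-diaminopentyl in place of 4-aminobutyl on an aromatic carbon. Going by the values given here, no measured step involves the entry of a second amino group; the only step on record, a number 7 percentage points lower from compound 1 to compound 2 (within the scatter), concerns chain length alone and was within the scatter. With nothing pointing in either direction, compound 3 is expected to land close to compound 2, with a number 3 percentage points higher from compound 2 to compound 3 (within the scatter) estimated to be no step beyond the scatter. Compound 3 is therefore estimated at 58%, within a range from 35% to 80%.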

Compound 3, a percentage reported as inhibition, at one concentration (the size of the read-out at that concentration, not a potency): 43%
Estimate against measurement, compound 3: 15 percentage points above, within the range that was stated.
By their numbers in this assay, from the lowest: compound 3; then compounds 2 and 1 (each within the scatter of the next).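

Lengthening the chain alone gave no step that could be told from the scatter, but at this aromatic carbon 1,5-diaminopentyl in place of 4-aminobutyl gives, in this assay, the step of a number 12 percentage points lower from compound 2 to compound 3 (beyond the scatter) and so the first change in this set that clears it. Read against the shortest compound, 4-aminobutyl in place of hydrogen on the saturated chain carbon gives a number 19 percentage points lower from compound 1 to compound 3 (beyond the scatter) as well. Compound 3, with its second amino group, therefore stands apart from both compounds with one, though both steps are modest.

As far as these compounds go, whether the second amino group or the defined stereocentre matters more stays open, as does how a hydroxyl group, an amide or a carboxylic acid in place of that amine would read. No measurement shown here bears on why the number falls.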